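The source may hold more compounds than are shown below. What is called first, only, known or untested is meant among the compounds shown, and "the series" means these compounds.

In an ADME assay on L132 cells (Homo sapiens) for cytotoxicity, read by MTT assay, with a stated time of 48 h (a lower number here means a stronger inhibitor, a higher number a weaker inhibitor), compound 3 `C/C(=C\CC/C(C)=C/CC[C@@H]1[C@@]2(C)CCC(=O)C(C)(C)[C@H]2CC[C@@]1(C)O)CC/C=C(\C)C(=O)OCc1cn(-c2ccccc2)nn1` reads > 150000 nM as a limit of the assay. Compound 1 `C/C(=C\CC/C(C)=C/CC[C@@H]1[C@@]2(C)CCC(=O)C(C)(C)[C@H]2CC[C@@]1(C)O)CC/C=C(\C)C(=O)OCc1cn(-c2ccccc2[N+](=O)[O-])nn1` reads > 150000 nM as a limit too. Compound 2 `COc1ccc(-n2cc(COC(=O)/C(C)=C/CC/C(C)=C/CC/C(C)=C/CC[C@@H]3[C@@]4(C)CCC(=O)C(C)(C)[C@H]4CC[C@@]3(C)O)nn2)cc1` reads > 150000 nM as a limit too. The series therefore stands at the limit of > 150000 nM in this assay, at which 3 of the 3 values shown sit, and holds no numeric value yet. Compound 4 `C/C(=C\CC/C(C)=C/CC[C@@H]1[C@@]2(C)CCC(=O)C(C)(C)[C@H]2CC[C@@]1(C)O)CC/C=C(\C)C(=O)OCc1cn(-c2ccc(C(C)(C)C)cc2)nn1` has tert-butyl in place of hydrogen on an aromatic carbon, para to a large group, counted as tert-butyl in place of hydrogen on an aromatic carbon here. The changes closest to this one are a step that the two limits leave unreadable from compound 1 to compound 3 and a step that the two limits leave unreadable from compound 2 to compound 3 and neither offers a size to carry over. The same holds for a step that the two limits leave unreadable from compound 1 to compound 2 as well. No step beyond the scatter is expected in this assay, and another limit is the likely report. The estimated step is a step that the limit leaves unreadable from compound 3 to compound 4 on this basis. For compound 4 the expected value is 200000 nM with an estimated range from 120000 nM to 400000 nM in this assay.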

Compound 4, half-maximal inhibitory concentration: 65800 nM
Compound 4: middle estimate off by 3.0-fold (0.48 log units), on the high side, and the stated range ends above it.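

Tert-butyl on the aromatic carbon, para to a large group, gives the first readable change in this assay: tert-butyl in place of hydrogen gives an at least 2.2-fold lower number from compound 3 to compound 4 (0.35 log units; beyond the scatter). Tert-butyl in place of methoxy gives an at least 2.2-fold lower number from compound 2 to compound 4 (0.35 log units; beyond the scatter), and 4-(tert-butyl)phenyl in place of 2-nitrophenyl gives an at least 2.2-fold lower number from compound 1 to compound 4 (0.35 log units; beyond the scatter). The steps among compound 1, compound 2 and compound 3 cannot be read, and compound 4 alone holds a number, with the others remaining limits: the limit of > 150000 nM in this assay, at which 3 of the 4 values shown sit.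

From the compounds shown here alone, the true size of each step remains open. Also open, going by these compounds, is whether a smaller methyl, an amine or a carboxylic acid at this carbon gives a numeric value.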